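The source may hold more compounds than are shown below. What is called first, only, known or untested is meant among the compounds shown, and "the series" means these compounds.

Measured so far in an assay on isolated protein for inhibition of protein deacetylase HDAC6 (Homo sapiens); on this read-out lower numbers stand for stronger inhibition and higher numbers for weaker inhibition:
- compound 1 `Cc1ccc(-c2noc(-c3ccc(C(=O)C(F)(F)F)s3)n2)cc1`: 860 nM
- compound 2 `O=C(c1ccc(-c2nc(-c3ccc(C(F)(F)F)cc3)no2)s1)C(F)(F)F`: 11000 nM

For the measured compounds named here, compound 2 stands at the highest of the two numbers; its only neighbour is compound 1, and the step of a 13-fold higher number from compound 1 to compound 2 (1.11 log units; beyond the scatter) was large. Compound 3 `CC(C)(C)c1ccc(-c2noc(-c3ccc(C(=O)C(F)(F)F)s3)n2)cc1` differs from compound 2 by tert-butyl in place of trifluoromethyl on an aromatic carbon. Going by the values given here, the one measured step that bears on this change is a 13-fold higher number from compound 1 to compound 2 (1.11 log units; beyond the scatter), which shows that removing trifluoromethyl from that position in favour of an alkyl group went with a much lower number. Compound 3 replaces trifluoromethyl with a different alkyl group, so a lower number is expected, with the step of a 7.3-fold lower number from compound 2 to compound 3 (0.87 log units; beyond the scatter) estimated. Compound 3 is therefore estimated at 1500 nM in this assay, within 400 nM to 6000 nM.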

Compound 3, half-maximal inhibitory concentration: 3540 nM
The estimate for compound 3 lay 2.4-fold (0.37 log units) below the measured number; measured number inside the range.
By their numbers in this assay, from the lowest: compound 1; then compound 3; then compound 2.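

Tert-butyl on the aromatic carbon para to a large group gives, in this assay, a 3.1-fold lower number from compound 2 to compound 3 (0.49 log units; beyond the scatter) and a 4.1-fold higher number from compound 1 to compound 3 (0.61 log units; beyond the scatter) as its two steps, so the bulkier alkyl group does not recover the number seen with methyl. Trifluoromethyl and tert-butyl have the same heavy-atom count yet differ beyond the scatter, so that count alone does not set the number here. Nothing measured on hand explains this order of the three groups.

Open, on these data alone, is how a methoxy group, a chlorine atom or an amine would read at this position. Also open, as far as these compounds go, is whether the same order holds when the trifluoroacetyl end of the core changes.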